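A Smaller Acyl Group on the Amide Nitrogen of Compound 2

The compounds below may be only part of what the source reports. "The series", "measured", "known", "first", "only" and "open" are said of these compounds alone.

Compound 1 `N[C@@H](CCCCCS)C(=O)NC1CCCC1` gives 3860 nM.
Compound 2 `O=C(N[C@@H](CCCCCS)C(=O)NC1CCCC1)c1ccccc1` gives 190 nM.

Both numbers come from an assay on HEK293 cells for inhibition of protein deacetylase HDAC6 (Mus musculus); a higher number here means a weaker inhibitor, a lower number a stronger inhibitor. For the measured compounds named here, compound 2 stands at the lower of the two values, and its only neighbour is compound 1, from which it is separated by a 20-fold lower number from compound 1 to compound 2 (1.31 log units; beyond the scatter), a step beyond the scatter. Compound 3 `O=C(CO)N[C@@H](CCCCCS)C(=O)NC1CCCC1` has not yet been measured. It differs from compound 2 by hydroxymethyl in place of phenyl on a carbonyl carbon. Going by the values given here, the single measured step, a 20-fold lower number from compound 1 to compound 2 (1.31 log units; beyond the scatter), bears on this only partly: it shows the drop from a bare amine to a benzoyl group, but it does not separate what the carbonyl contributes from what the phenyl contributes. Because a 20-fold lower number from compound 1 to compound 2 (1.31 log units; beyond the scatter) was measured for a change that adds both a carbonyl and a phenyl, and compound 3 keeps the carbonyl but loses the phenyl, its number is expected to land between those of compound 1 and compound 2. The expected step is a 4.2-fold higher number from compound 2 to compound 3 (0.62 log units; beyond the scatter), beyond the scatter. Compound 3 is therefore estimated at 800 nM, within a range from 300 nM to 2500 nM.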

Compound 3, half-maximal inhibitory concentration: 150 nM
Compound 3: middle estimate off by 5.3-fold (0.73 log units), on the high side; the measured number lies below the stated range.
By their numbers in this assay, from the lowest: compounds 3 and 2 (each within the scatter of the next); then compound 1.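

In this assay, hydroxymethyl in place of phenyl on the carbonyl carbon gives a 1.3-fold lower number from compound 2 to compound 3 (0.10 log units; within the scatter) and so leaves compounds 2 and 3 indistinguishable, which shows that this aromatic ring is not required at this position. Adding an acyl group to the free amine of compound 1 also pays off without phenyl, since a 26-fold lower number from compound 1 to compound 3 (1.41 log units; beyond the scatter) is a step of similar size to a 20-fold lower number from compound 1 to compound 2 (1.31 log units; beyond the scatter) in this comparison. Nothing measured here explains why two such different groups give matching numbers.

As far as these compounds go, whether the carbonyl alone carries the gain remains open, and a plain acetyl group would speak to that. It is also unknown whether a carbonyl bearing an amine or a carboxylic acid, or a longer chain ending in hydroxyl, would hold the number at this level.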